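Ring Oxygen to Ring Sulfur Beside the Sulfonyl

This account rests on a few compounds, and the source may have more. Where it says the series, first, only, none or still open, it means among the compounds named here.

Compound 1 `O=S(=O)(CC1=NCCO1)C1C(c2ccc(Cl)cc2)=NN(c2ccccc2)C1c1ccc(Cl)cc1`: "not active" (no number reported)
Compound 2 `COc1ccc(C2=NN(c3ccccc3)C(c3ccc(C)cc3)C2S(=O)(=O)CC2=NCCO2)cc1`: 64.9%
Compound 3 `O=S(=O)(CC1=NCCS1)C1C(c2ccccc2)=NOC1c1ccccc1`: "not active" (no number reported)

Among the measured compounds shown here, in a functional assay, read by Griess assay, with a stated time of 150 min, tested at 75 ug/mL (a higher number here means a stronger effect of the compound at the concentration tested, a lower number a weaker effect), compound 2 gives 64.9%, and it is the only compound of the three for which a number is reported at all; compound 1 is reported as "not active" (no number reported) and compound 3 as "not active" (no number reported), without a number. For the measured compounds named here, compound 2 therefore stands alone as the one compound with a measured effect, and no step between two measured compounds is available to calibrate a structural change.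

Compound 4 `COc1ccc(C2=NN(c3ccccc3)C(c3ccc(C)cc3)C2S(=O)(=O)CC2=NCCS2)cc1` differs from compound 2 in one place: a group of 5 heavy atoms (3 carbon, 1 nitrogen, 1 sulfur; one five-membered non-aromatic ring with 2 hetero atoms) in place of a group of 5 heavy atoms (3 carbon, 1 nitrogen, 1 oxygen; one five-membered non-aromatic ring with 2 hetero atoms), on a saturated chain carbon bound to a sulfonyl sulfur. The change exchanges one ring of the five-membered non-aromatic kind for another, keeping the count of heavy atoms, donors and acceptors the same. Compound 3 carries the sulfur-containing ring and is not active, but it differs from compound 2 in far more than that ring, so it says nothing firm about the step from compound 2 to compound 4.

Going by the values given here, with no step to rest on, a change no larger than the scatter is expected, a number 9.9 percentage points lower from compound 2 to compound 4 (within the scatter). Compound 4 is estimated to give 55%, within the range 25% to 80%.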

Compound 4, a percentage reported as activity, at one concentration (the size of the read-out at that concentration, not a potency): 44.9%
Estimate against measurement, compound 4: 10.1 percentage points above, within the range that was stated.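

Among the compounds shown here, the first step comes from the ring itself: in this assay, putting the sulfur-containing ring in place of the oxygen-containing ring, on a saturated chain carbon bound to a sulfonyl sulfur, gives a number 20 percentage points lower from compound 2 to compound 4 (beyond the scatter). For the compounds shown here, this shows what the earlier compounds could not, that this position responds to a single ring atom even though the count of heavy atoms, donors and acceptors stays the same, while compound 4 still keeps a measurable effect at 44.9%. Nothing available explains why the sulfur-containing ring gives the lower number, so the step stands as an observation about this one pair on this one core.

Going by these compounds alone, whether the same exchange gives a step of similar size when the aromatic groups on the shared core are different remains open, since this single pair is the only comparison that can be read. Also open, as far as these compounds go, is how far the position tolerates something other than these two rings, such as an open-chain amine, a carboxylic acid or a six-membered morpholine ring on the same chain carbon.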